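A flat amide series meets 4-methoxyphenyl

This account rests on a few compounds, and the source may have more. Where it says the series, first, only, none or still open, it means among the compounds named here.

Compound 1 `CC(=O)N(C)c1ccc2[nH]c(-c3n[nH]c4ccccc34)cc2n1` gives 5110 nM
Compound 2 `CCC(=O)N(C)c1ccc2[nH]c(-c3n[nH]c4ccccc34)cc2n1` gives 6130 nM
Compound 3 `CN(C(=O)CCc1ccccc1)c1ccc2[nH]c(-c3n[nH]c4ccccc34)cc2n1` gives 4730 nM

In a functional assay on HL-60 cells (Homo sapiens) for antiproliferative activity, read by MTT assay, with a stated time of 72 h (a higher number here means a weaker inhibitor, a lower number a stronger inhibitor), compound 3 cannot be told apart from the other two. The steps of a 1.2-fold higher number from compound 1 to compound 2 (0.08 log units; within the scatter) and a 1.1-fold lower number from compound 1 to compound 3 (0.03 log units; within the scatter) and also a 1.3-fold lower number from compound 2 to compound 3 (0.11 log units; within the scatter) all stay small. Compound 4 `COc1ccc(C(=O)N(C)c2ccc3[nH]c(-c4n[nH]c5ccccc45)cc3n2)cc1` brings one change, 4-methoxyphenyl in place of phenethyl on a carbonyl carbon in the form of 4-methoxyphenyl in place of phenethyl on a carbonyl carbon. The three measured steps bear on this only loosely. Each alters the group on that carbonyl carbon, yet none of these compounds carries 4-methoxyphenyl there. No step beyond the scatter is therefore expected in this assay and no direction can be given with confidence. The expected step is a 1.1-fold higher number from compound 3 to compound 4 (0.02 log units; within the scatter) by this estimate. Compound 4 is estimated at 5000 nM (expected range 2000 nM to 12000 nM).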

Compound 4, half-maximal inhibitory concentration: 3320 nM
Estimate against measurement, compound 4: 1.5-fold (0.18 log units) above; measured number inside the range.
By their numbers in this assay, from the lowest: compounds 4, 3, 1 and 2 (each within the scatter of the next).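

In this assay, among the compounds shown here, 4-methoxyphenyl is the first group in this set with an aromatic ring bound directly to the carbonyl carbon, and it still gives no step beyond the scatter against phenethyl (a 1.4-fold lower number from compound 3 to compound 4 (0.15 log units; within the scatter)), ethyl (a 1.8-fold lower number from compound 2 to compound 4 (0.27 log units; within the scatter)) or methyl (a 1.5-fold lower number from compound 1 to compound 4 (0.19 log units; within the scatter)). Across these four compounds, then, the group on this carbonyl carbon, whose other neighbour is the amide-type nitrogen, can be a short chain, a phenethyl or a 4-methoxyphenyl carrying a hydrogen-bond acceptor without a readable change in the number. Nothing available explains why the number stays so level across these groups.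

On these data alone, what the methoxy contributes apart from the ring stays open, and a plain phenyl on that carbonyl carbon would bear on this. As far as these compounds go, whether an amine or a carboxylic acid there would give a step beyond the scatter also stays open.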